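Swapping a Thiadiazole for a Pyrimidine on Sulfur

The compounds below may be only part of what the source reports. "The series", "measured", "known", "first", "only" and "open" are said of these compounds alone.

Among the compounds with values here, compound 3 `COc1ccc(-c2cs/c(=N/NC(=O)CSc3nnc(C)s3)n2-c2ccccc2)cc1` is the only compound in this set with a measured number: in a functional assay on C6 cells (Rattus norvegicus) for cytotoxicity, read by MTT assay, with a stated time of 24 h (a higher number here means a weaker inhibitor, a lower number a stronger inhibitor), compound 3 gives 18.7 ug/mL. Two related compounds share the same core but carry a pyrimidin-2-yl on the sulfur. Compound 2 `O=C(CSc1ncccn1)N/N=c1/scc(-c2ccc(Br)cc2)n1-c1ccccc1` in this assay gives only a limit, > 200 ug/mL, a reading summarized as the limit of > 200 ug/mL in this assay, at which 1 of the 3 values shown sits. Compound 1 `N#Cc1ccc(-c2cs/c(=N/NC(=O)CSc3ncccn3)n2-c2ccccc2)cc1` has "not determined" (no result reported) in this assay. Compound 4 `COc1ccc(-c2cs/c(=N/NC(=O)CSc3ncccn3)n2-c2ccccc2)cc1` has not yet been tested in this assay.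

Compound 4 differs from compound 3 in one place: pyrimidin-2-yl in place of 5-methyl-1,3,4-thiadiazol-2-yl on a sulfur. Within the data shown here, no pair of measured compounds differing in a single place exists here, so there is no measured step to lean on. Among the measured compounds shown here, what can be said is that compound 3 holds the one numerical value, while compound 2, which carries the same pyrimidin-2-yl group that enters in compound 4, reached only a limit. On that basis the step is expected to run toward weaker inhibition rather than stronger, although a step within the scatter cannot be ruled out. The estimated change is a 3.2-fold higher number from compound 3 to compound 4 (0.51 log units; beyond the scatter). Compound 4 is expected to give about 60 ug/mL in this assay, with a likely range from 15 ug/mL to 200 ug/mL, and a real chance that only a limit is reported.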

Compound 4, half-maximal inhibitory concentration: 102 ug/mL
For compound 4 the middle estimate is 1.7-fold (0.23 log units) below the measured one; the range from low to high includes it.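

The swap of 5-methyl-1,3,4-thiadiazol-2-yl for pyrimidin-2-yl on this sulfur, with the rest of the molecule unchanged, gives in this assay a 5.5-fold higher number from compound 3 to compound 4 (0.74 log units; beyond the scatter), which shows that the group held by this sulfur matters to the reading and that the two rings are not interchangeable here. Compound 2 carries the same pyrimidin-2-yl group but has bromo where compound 4 has methoxy, and it reaches only a limit: the limit of > 200 ug/mL in this assay, at which 1 of the 4 values shown sits. Going from bromo to methoxy on that aromatic carbon gives an at least 1.9-fold lower number from compound 2 to compound 4 (0.29 log units; that floor lies within the scatter), and as this figure is only a floor, the true size of the step stays unknown, though the pyrimidin-2-yl group clearly does not by itself decide the reading.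

A single step at this sulfur cannot show which difference between the two rings drives the change, whether the methyl group, the ring size or the ring sulfur. A phenyl group or a 5-methyl-1,3,4-oxadiazol-2-yl group on the same sulfur, each set against compound 3 and compound 4, would help to separate these differences.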